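Trimethoxyphenyl amides: ethynyl to bromomethyl on the carbonyl

This account rests on a few compounds, and the source may have more. Where it says the series, first, only, none or still open, it means among the compounds named here.

Measured so far:
compound 1 `C#CC(=O)N(Cc1ccc(OC)c(O)c1)c1cc(OC)c(OC)c(OC)c1` gives 170 nM
compound 2 `C/C=C/C(=O)N(Cc1ccc(OC)c(Cl)c1)c1cc(OC)c(OC)c(OC)c1` gives 7100 nM

In a functional assay on MGC-803 cells (Homo sapiens) for inhibition, read by MTT assay, with a stated time of 48 h (a lower number here means a stronger inhibitor, a higher number a weaker inhibitor), compound 1 holds the lowest number of the two; compound 2 differs from it in more than one place, so only the two values are compared, and the gap between them lies beyond the scatter. Compound 3 `COc1ccc(CN(C(=O)CBr)c2cc(OC)c(OC)c(OC)c2)cc1O` is not yet measured. It differs from compound 1 in one place: bromomethyl in place of ethynyl on a carbonyl carbon. Going by the values given here, no step between measured compounds covers this change, so the expectation rests on the value of compound 1 alone. The step of a 1.5-fold higher number from compound 1 to compound 3 (0.17 log units; within the scatter) in this assay is expected to be small, either within the scatter or a modest move toward a higher number. Compound 3 is therefore estimated at 250 nM in this assay, with a range from 60 nM to 1000 nM, anchored on compound 1 at 170 nM.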

Compound 3, half-maximal inhibitory concentration: 140 nM
Beside the measured number, compound 3's estimate is 1.8-fold (0.25 log units) above it, within the range that was stated.
By their numbers in this assay, from the lowest: compounds 3 and 1 (each within the scatter of the next); then compound 2.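

In this assay the change of bromomethyl in place of ethynyl on a carbonyl carbon reads a 1.2-fold lower number from compound 1 to compound 3 (0.08 log units; within the scatter) and so stays within the scatter. Going by these compounds alone, this is the first reading of a single change at this position, with the rest of the core of compound 1 held fixed; compound 1 and compound 2 differ in more than one place and could not give one. On this core, the two groups are not told apart by this assay, and no measurement at hand accounts for that.

Open, as far as these compounds go, is whether this level holds for other groups on the carbonyl carbon, such as chloromethyl, plain methyl or a longer chain. Also open, from the compounds shown here alone, is whether bromomethyl gives a similar number on the core of compound 2.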